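From thiophen-2-yl to 3-fluoropyridin-2-yl on compound 2

The source may report more compounds than this note shows. Statements on the series, on what has been measured and on what is new or still open speak of the compounds shown alone.

Compound 1 `Cn1c(Sc2ccc(C(=O)NO)cc2)nnc1-c1cccs1` gives 82%
Compound 2 `Cn1c(Sc2c(F)cc(C(=O)NO)cc2F)nnc1-c1cccs1` gives 71%
Compound 3 `O=C(NO)c1cc(F)c(Cc2nnc(-c3ccncc3)s2)c(F)c1` gives 32%

For the measured compounds named here, these three numbers come from an ADME assay on S9 fraction from liver (Rattus norvegicus) for metabolic stability, read by LC-MS, using NADPH, with a stated time of 90 min, tested at 5 uM (a lower number here means that less of the compound is left, a higher number that more of the compound is left), and are the only guide available here. Compound 2 at 71% is the second highest of the three. Compound 1 stands higher and compound 3 lower, and both gaps lie beyond the usual scatter.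

Compound 4 `Cn1c(Sc2c(F)cc(C(=O)NO)cc2F)nnc1-c1ncccc1F` has not yet been measured. It keeps the core of compound 2 and changes one group, with 3-fluoropyridin-2-yl in place of thiophen-2-yl on an aromatic carbon. Going by the values given here, no measured pair shows this swap on its own, so there is no direct step to borrow.

In this assay compound 3, which also carries a six-membered aromatic ring, gives 32% but differs from compound 2 in other places too, so it argues only weakly for a fall. The expected step of a number 8 percentage points lower from compound 2 to compound 4 (within the scatter) is therefore a small fall that may well stay within the scatter. For compound 4 the estimated value is 63% with an expected range from 42% to 82% on repeated measurement.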

Compound 4, percent of the compound remaining: 70%
Estimate against measurement, compound 4: 7 percentage points below; low and high end bracket the measured number.
By their numbers in this assay, from the lowest: compound 3; then compounds 4 and 2 (each within the scatter of the next); then compound 1.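

In this assay, for the compounds shown here, replacing thiophen-2-yl with 3-fluoropyridin-2-yl on this aromatic carbon of the shared core gives a step of a number 1 percentage points lower from compound 2 to compound 4 (within the scatter), and this is the first pair here that differs in one place only. The five-membered aromatic ring with a sulfur can therefore give way at this position to a six-membered aromatic ring with a ring nitrogen and a fluorine, with 7 heavy atoms instead of 5, and the share of compound left after incubation stays within the scatter. Nothing measured here explains why these two groups read alike.

On these data alone, with a single pair at this position, it remains open whether the same reading would hold for a plain phenyl, for pyridin-2-yl without the fluorine, or for a small group such as methyl. As far as these compounds go, it is also open whether this swap would read the same way on the core of compound 1, since a single step on the core of compound 2 cannot show whether the result depends on the rest of the molecule.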